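The source may hold more compounds than are shown below. What is called first, only, known or untested is meant among the compounds shown, and "the series" means these compounds.

Compound 1 `CNC(=O)c1cc(Oc2ccc3nc(Nc4cccc(C(C)(C)C)c4)ccc3c2)ccn1` and compound 2 `CNC(=O)c1cc(Oc2ccc3nc(Nc4cccc(Cl)c4)ncc3c2)ccn1` share the core that carries the amide-bearing pyridyl ether; compound 1 bears a tert-butylphenyl amine and compound 2 a 3-chlorophenyl amine. In a physicochemical assay for solubility, at pH 7 (on this read-out lower numbers stand for lower solubility and higher numbers for higher solubility), compound 1 gives < 1000 nM, a limit of the assay rather than a number. In this assay compound 2 also gives only a limit, < 1000 nM. For the measured compounds named here, both values therefore sit at the limit of < 1000 nM in this assay, at which 2 of the 2 values shown sit; no step between measured compounds can be sized. Compound 3 `CNC(=O)c1cc(Oc2ccc3nc(Nc4ccc(Br)cc4)ncc3c2)ccn1` differs from compound 2 by 4-bromophenyl in place of 3-chlorophenyl on a nitrogen on an aromatic ring. No step beyond the scatter is expected from compound 2 to compound 3, a step that the limit leaves unreadable from compound 2 to compound 3. Compound 3 is estimated at 400 nM, between 80 nM and 2000 nM, most likely again reported as a limit.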

Compound 3, solubility: < 1000 nM
Compound 3: a limit, no number; the forecaster's own chance of this, stated with the estimate: 80%; the middle value lies beyond the limit too.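

Compound 3 gives only a limit in this assay, as compound 2 does, so no step between compound 2 and compound 3 can be read: the limit of < 1000 nM in this assay, at which 3 of the 3 values shown sit.

The compounds shown leave open how soluble each one actually is, and whether 4-bromophenyl and 3-chlorophenyl differ at all on this read-out.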